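A few compounds are considered here, and "the series" means these few. Any claim that something is new, unique, unknown or untested is made for them only; others in the source may bear on it.

The measured compounds are compound 1 `COc1ccc(/C=C/C2CC(=O)C=CO2)cc1OC` with 130 uM, compound 2 `COc1cc(/C=C/C2CC(=O)C=CO2)cc(OC)c1OC` with 149 uM and compound 3 `COc1ccc(/C=C/C2CC=CC(=O)O2)cc1OC` with 7.8 uM, all in a functional assay on MCF7 cells (Homo sapiens) for inhibition, read by sulforhodamine B assay, with a stated time of 48 h; on this read-out lower numbers stand for stronger inhibition of growth and higher numbers for weaker inhibition of growth.

Compounds 1 and 2 differ by one change, (methoxy in place of hydrogen on an aromatic carbon), and that change gave a 1.1-fold higher number from compound 1 to compound 2 (0.06 log units; within the scatter). Compound 3 has the same atoms as compound 1 joined differently; the difference between the two cores is not broken down here. Its number stands well apart from both, the lowest of the three.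

Compound 4 `COc1cc(OC)c(OC)cc1/C=C/C1CC=CC(=O)O1` is not yet measured. It differs from compound 3 by methoxy in place of hydrogen on an aromatic carbon. This is the same kind of change as from compound 1 to compound 2, though not the same: in compound 4 the entering methoxy sits ortho to the group of 9 heavy atoms, meta to a methoxy group and para to a methoxy group, whereas in compound 2 it sits ortho to a methoxy group, meta to the group of 9 heavy atoms and meta to a methoxy group. Because the earlier step was a 1.1-fold higher number from compound 1 to compound 2 (0.06 log units; within the scatter), a similarly small step of a 1.3-fold higher number from compound 3 to compound 4 (0.11 log units; within the scatter) is expected for compound 4 in this assay. Compound 4 is therefore estimated at 10 uM.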

Compound 4, concentration for growth inhibition (reported as GI): 3.8 uM
Compound 4: middle estimate off by 2.6-fold (0.42 log units), on the high side; measured number outside the range, below it.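

In this assay, the methoxy gave a 2.1-fold lower number from compound 3 to compound 4 (0.31 log units; beyond the scatter), a modest step, set against a 1.1-fold higher number from compound 1 to compound 2 (0.06 log units; within the scatter) on the other core. The two steps cannot be told apart: the same change on two cores in this assay, a 1.1-fold higher number (0.06 log units; within the scatter) from compound 1 to compound 2 and a 2.1-fold lower number (0.31 log units; beyond the scatter) from compound 3 to compound 4, 2.4-fold (0.37 log units) apart, within the scatter of two such steps. Among these compounds, this shows no measurable dependence of the step on the core, but with only two steps, and with the methoxy at different places on the aromatic ring, it does not show that the change carries reliably from one core to the other.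

The compounds shown leave open what a hydroxyl, an amine or a fluorine would do in place of the entering methoxy. They also leave open what the methoxy would do on the core of compound 3 at the place it holds in compound 2.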